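One Halogen for Another on a Shared Core

A few compounds are considered here, and "the series" means these few. Any claim that something is new, unique, unknown or untested is made for them only; others in the source may bear on it.

Compound 1 `O=C(/C=C/C1=Cc2ccccc2OC1)c1ccc(F)cc1` stands highest of the two measured compounds in a functional assay on the whole organism for inhibition, with Mus musculus as the target, with a stated time of 1 h, at a dose of 30 mg/kg by the intraperitoneal route (on this read-out lower numbers stand for less inhibition and higher numbers for more inhibition at the one dose given (going by the name of the read-out)), where compound 1 gives 65.6%. Compound 2 `O=C(/C=C/C1=Cc2ccccc2OC1)c1ccc(Cl)cc1Cl` gives 53.3%, a number that sits below compound 1 by more than the usual scatter. Compound 3 `O=C(/C=C/C1=Cc2ccccc2OC1)c1cccc(Br)c1` keeps the shared core and differs from compound 1 in one place: 3-bromophenyl in place of 4-fluorophenyl on a carbonyl carbon. Going by the values given here, no measured pair shows what this change does on its own, so its direction cannot be read from the numbers already known. The two measured values only show that altering the group on the carbonyl carbon can move the read-out, and a moderate step downward is expected here, while a step within the scatter would not be surprising. Compound 3 is therefore expected to give 55%, within a range from 35% to 72%. The expected step is a number 10.6 percentage points lower from compound 1 to compound 3 (beyond the scatter).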

Compound 3, a percentage reported as inhibition, in the whole organism at one dose (the size of the read-out at that dose, not a potency): 51.7%
The estimate for compound 3 lay 3.3 percentage points above the measured number, within the range that was stated.
By their numbers in this assay, from the lowest: compounds 3 and 2 (each within the scatter of the next); then compound 1.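

Swapping 4-fluorophenyl for 3-bromophenyl on a carbonyl carbon gives the first comparison that changes only this one place on the shared core, and in this assay the change gives a number 13.9 percentage points lower from compound 1 to compound 3 (beyond the scatter), so this position does respond to a single change of group. The two groups have the same heavy-atom count and differ in both the halogen and the number in the group's name, so the step cannot be assigned to either difference alone. Nothing available explains the step.

A 4-bromophenyl or 3-fluorophenyl group would separate the halogen from its location, while an unsubstituted phenyl group would show what either halogen adds. An aminophenyl or carboxyphenyl group would test whether this position accepts anything beyond a halogen-bearing ring.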